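Swapping the Heteroaryl on the Cyclic Carbamate Nitrogen

The source may report more compounds than this note shows. Statements on the series, on what has been measured and on what is new or still open speak of the compounds shown alone.

Compound 1 `O=C1O[C@]2(CC[C@H](CNc3cnn(-c4ccccc4F)c3)CC2)CN1c1cncnc1`: 0.0398 nM
Compound 2 `O=C1O[C@]2(CC[C@H](CNc3cnn(-c4ccccc4F)c3)CC2)CN1c1cccnc1F`: 0.1 nM
Compound 3 `O=C1O[C@]2(CC[C@H](CNc3ccc(-c4cc(F)cc(F)c4)nn3)CC2)CN1c1cccnn1`: 0.1 nM

In a functional assay for antagonist activity at Neuropeptide Y receptor type 5 (Homo sapiens) (on this read-out higher numbers stand for weaker inhibition and lower numbers for stronger inhibition), compound 2 gives 0.1 nM, level with compound 3 at the digits shown and together the highest of the three numbers; compound 1 sits furthest away, with a 2.5-fold higher number from compound 1 to compound 2 (0.40 log units; beyond the scatter) separating the two. Compound 4 `O=C1O[C@]2(CC[C@H](CNc3cnn(-c4ccccc4F)c3)CC2)CN1c1cccnn1` is not yet measured. It differs from compound 2 as follows: pyridazin-3-yl in place of 2-fluoropyridin-3-yl on an amide-type nitrogen in a ring. For the measured compounds named here, the only measured step that bears on this change is the one on the same ring nitrogen, from compound 1 to compound 2, a modest move of a 2.5-fold higher number from compound 1 to compound 2 (0.40 log units; beyond the scatter). Compound 3 already carries pyridazin-3-yl on that nitrogen, though with a different side chain, and gives 0.1 nM. A small step within the scatter is therefore expected, a 1.7-fold lower number from compound 2 to compound 4 (0.22 log units; within the scatter). Compound 4 is estimated at 0.06 nM, with a range from 0.02 nM to 0.2 nM.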

Compound 4, inhibition constant: 0.1 nM
Beside the measured number, compound 4's estimate is 1.7-fold (0.22 log units) below it; measured number inside the range.
By their numbers in this assay, from the lowest: compound 1; then compounds 2, 3 and 4 (each within the scatter of the next).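

In this assay, the step of no change at the digits printed from compound 2 to compound 4 (within the scatter) shows that pyridazin-3-yl and 2-fluoropyridin-3-yl cannot be told apart on this amide-type nitrogen in a ring. The step of a 2.5-fold higher number from compound 1 to compound 4 (0.40 log units; beyond the scatter) then shows that, with this side chain, pyrimidin-5-yl alone of the three groups stands apart, giving the lower number. No evidence at hand bears on this result. As far as these compounds go, it remains open how a phenyl or pyrimidin-2-yl group would read on this nitrogen, and whether pyrimidin-5-yl keeps its lower number with the side chain of compound 3.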